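The source may report more compounds than this note shows. Statements on the series, on what has been measured and on what is new or still open speak of the compounds shown alone.

Measured so far in a functional assay on A-375 cells (Homo sapiens) for inhibition, read by CCK-8 assay, with a stated time of 72 h, tested at 8 uM; a lower number here means less inhibition of growth, a higher number more inhibition of growth at the concentration tested:
- compound 1 `Cc1ccc(SCc2ccc(/C=C/C(=O)Nc3ccccc3N)cc2)cc1`, giving 31.2%
- compound 2 `Nc1ccccc1NC(=O)c1ccc(CSc2ccc(C(F)(F)F)cn2)cc1`, giving 5.34%

Of these two numbers, compound 1 holds the higher one, and the gap to compound 2 lies beyond the usual scatter. Compound 3 `Nc1ccccc1NC(=O)/C=C/c1ccc(CSc2cccc(F)c2)cc1` keeps the core of compound 1 and differs from it in one place: 3-fluorophenyl in place of 4-methylphenyl on a sulfur. Within the data shown here, with no comparable step measured, a change of this kind is expected to move the number only a little, likely downward but perhaps not beyond the scatter, so the step of a number 5.2 percentage points lower from compound 1 to compound 3 (within the scatter) is expected to be small. Compound 3 is therefore estimated at 26%, within 12% to 40%.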

Compound 3, percent growth inhibition at one concentration: 9.08%
Compound 3: the middle estimate sits 16.9 percentage points above what was measured; the measured number lies below the stated range.
By their numbers in this assay, from the lowest: compounds 2 and 3 (each within the scatter of the next); then compound 1.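

In this assay the group on the sulfur clearly matters: 3-fluorophenyl in place of 4-methylphenyl gives a number 22.1 percentage points lower from compound 1 to compound 3 (beyond the scatter), although the two groups have the same heavy-atom count. Even a swap this small at this position can therefore change growth inhibition. Nothing available explains the size of this drop.

The step changes both the substituent and its place on the ring, so the compounds shown cannot separate these two changes. Unsubstituted phenyl, 4-fluorophenyl or 3-methylphenyl on the sulfur would help to tell them apart.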